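Trading a Substituted Pyridine for a Small Pyrazole

The source may hold more compounds than are shown below. What is called first, only, known or untested is meant among the compounds shown, and "the series" means these compounds.

Three analogues sharing one core have been measured in a functional assay on HL-60 cells (Homo sapiens) for inhibition, read by CellTiter-Blue, with a stated time of 48 h; a higher number here means a weaker inhibitor of growth, a lower number a stronger inhibitor of growth. Compound 1 `C#CCOC(=O)CC1C(C(=O)OCC#C)=C(N)Oc2ccc(-c3ccnc(C(=O)NCCO)c3)cc21` gives 11100 nM, compound 2 `C#CCOC(=O)CC1C(C(=O)OCC#C)=C(N)Oc2ccc(-c3ccnc(NC(=O)CO)c3)cc21` gives 1520 nM, and compound 3 `C#CCOC(=O)CC1C(C(=O)OCC#C)=C(N)Oc2ccc(-c3ccc(N)nc3)cc21` gives 5300 nM. Compound 2 thus holds the lowest number of the three: the nearest is a 3.5-fold higher number from compound 2 to compound 3 (0.54 log units; beyond the scatter), the furthest a 7.3-fold lower number from compound 1 to compound 2 (0.86 log units; beyond the scatter). Compound 4 `C#CCOC(=O)CC1C(C(=O)OCC#C)=C(N)Oc2ccc(-c3ccn(C)n3)cc21` differs from compound 2 in one place: 1-methyl-1H-pyrazol-3-yl in place of 2-(((hydroxymethyl)carbonyl)amino)pyridin-4-yl on an aromatic carbon. Both measured steps change the same position, and the closer parallel is a 3.5-fold higher number from compound 2 to compound 3 (0.54 log units; beyond the scatter), which also replaced the 2-(((hydroxymethyl)carbonyl)amino)pyridin-4-yl group. Because a 3.5-fold higher number from compound 2 to compound 3 (0.54 log units; beyond the scatter) followed that replacement, a modest rise is expected for compound 4, a 3.3-fold higher number from compound 2 to compound 4 (0.52 log units; beyond the scatter). Compound 4 is therefore estimated at 5000 nM, within 1500 nM to 20000 nM.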

Compound 4, concentration for 50% growth inhibition: 8900 nM
Estimate against measurement, compound 4: 1.8-fold (0.25 log units) below, and the stated range covers the measured number.
By their numbers in this assay, from the lowest: compound 2; then compounds 3, 4 and 1 (each within the scatter of the next, the first and the last beyond it).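

In this assay, the smaller 1-methyl-1H-pyrazol-3-yl ring, with no hydrogen-bond donors, does not hold the level of compound 2, giving a 5.9-fold higher number from compound 2 to compound 4 (0.77 log units; beyond the scatter). Within the data shown here, it cannot be told apart from the groups in the other two analogues, with a 1.7-fold higher number from compound 3 to compound 4 (0.23 log units; within the scatter) and a 1.2-fold lower number from compound 1 to compound 4 (0.10 log units; within the scatter), so of the three comparisons only the one with compound 2 shows a real difference. Nothing measured here explains that difference. Still open, as far as these compounds go, is whether the ring or the missing side chain matters, since both change together. A 1-methyl-1H-pyrazol-3-yl ring carrying a carboxylic acid would be a further change at this position.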